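A few compounds are considered here, and "the series" means these few. Any claim that something is new, unique, unknown or untested is made for them only; others in the source may bear on it.

Working notes on the series. Compound 1 `Cc1c(/C=N\O)cc(-c2ccc(S(C)(=O)=O)cc2)n1-c1cccc(F)c1` opens the set. In an assay on J774 cells for inhibition of prostaglandin G/H synthase 1 (Mus musculus), read by immunoassay, with stated times of 15 min and 30 min (on this read-out higher numbers stand for weaker inhibition and lower numbers for stronger inhibition), compound 1 gives only a limit, > 10000 nM. Compound 2 `Cc1c(/C=N\O)cc(-c2ccc(S(C)(=O)=O)cc2)n1-c1ccc(F)c(F)c1` differs from it by one fluoro in place of hydrogen on an aromatic carbon. In this assay compound 2 likewise gives only a limit, > 10000 nM. The step from compound 1 to compound 2 is a step that the two limits leave unreadable from compound 1 to compound 2, so it tells neither the size nor the direction of that fluoro change. Compound 2 therefore stands at the limit of > 10000 nM in this assay, at which 2 of the 2 values shown sit; no number puts it within or beyond the scatter of any other compound shown.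

Compound 3 `Cc1c(/C=N\O)cc(-c2ccc(S(C)(=O)=O)cc2)n1-c1ccccc1` is the next change: phenyl in place of 3,4-difluorophenyl on an aromatic nitrogen. Among the measured compounds shown here, the only measured step that touches this change is the one from compound 1 to compound 2, and it is unreadable, so it offers no guide to size. For the measured compounds named here, with both values shown sitting at the limit, no step in this assay is expected beyond the scatter in either direction, and the most likely outcome for compound 3 is again a limit. The estimate for compound 3 is 15000 nM, with a range from 5000 nM to 50000 nM. The expected step is a step that the limit leaves unreadable from compound 2 to compound 3.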

Compound 3, half-maximal inhibitory concentration: > 10000 nM
Compound 3 gave a limit, no number; the forecaster's own chance of this, stated with the estimate: 85%; the middle value is on the limit's open side.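

In this assay compound 3 also gives only a limit, > 10000 nM. The steps among compound 1, compound 2 and compound 3 therefore cannot be read, in size or in direction: the limit of > 10000 nM in this assay, at which 3 of the 3 values shown sit.

The compounds shown leave open whether the fluoro changes on the phenyl group alter this inhibition at all.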